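Series notes: aryl piperazine variation, compound 2 to compound 3

A few compounds are considered here, and "the series" means these few. Any claim that something is new, unique, unknown or untested is made for them only; others in the source may bear on it.

Measured so far:
compound 1, `COc1ccc(N2CCN([C@@H]3CN[C@H](C(=O)N4CCSC4)C3)CC2)cc1`, 16.9 nM
compound 2, `O=C([C@@H]1C[C@H](N2CCN(c3ccc(Cl)cn3)CC2)CN1)N1CCSC1`, 3.1 nM

Both values come from an assay on a cell-free system (plasma) for inhibition of Dipeptidyl peptidase 4 (Rattus norvegicus), read by fluorescence; a lower number here means a stronger inhibitor, a higher number a weaker inhibitor. Among the measured compounds shown here, compound 2 holds the lowest number of the two, and the single measured step, a 5.5-fold lower number from compound 1 to compound 2 (0.74 log units; beyond the scatter), is the only guide to what changes on this ring nitrogen do. Compound 3, `N#Cc1ccc(N2CCN([C@@H]3CN[C@H](C(=O)N4CCSC4)C3)CC2)cc1`, is not yet measured; it differs from compound 2 by 4-cyanophenyl in place of 5-chloropyridin-2-yl on an amine nitrogen in a ring. For the measured compounds named here, no measured pair shows this particular exchange, so the step is expected to fall between no change and a modest rise, giving a 2.3-fold higher number from compound 2 to compound 3 (0.35 log units; beyond the scatter). For compound 3 the estimate in this assay is 7 nM, within 2.5 nM to 20 nM.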

Compound 3, half-maximal inhibitory concentration: 4.7 nM
Compound 3: middle estimate off by 1.5-fold (0.17 log units), on the high side; measured number inside the range.
By their numbers in this assay, from the lowest: compounds 2 and 3 (each within the scatter of the next); then compound 1.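

In this assay, 4-cyanophenyl in place of 5-chloropyridin-2-yl on the ring amine nitrogen gives a 1.5-fold higher number from compound 2 to compound 3 (0.18 log units; within the scatter), so this position accepts an aromatic ring of carbon only as well as one with a hetero atom. Cyano in place of methoxy on the aromatic carbon gives a 3.6-fold lower number from compound 1 to compound 3 (0.56 log units; beyond the scatter), so a ring hetero atom is not required for a number beyond the scatter of compound 1. Nothing available explains either step.

Still open, going by these compounds, is how a carboxylic acid or an amine on the aromatic carbon would read in this assay. Also open, on these data alone, is whether a saturated ring such as cyclohexyl can replace the aromatic ring on this nitrogen.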